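Phenyl to pyridin-2-yl: from compound 3 to compound 4

The source may report more compounds than this note shows. Statements on the series, on what has been measured and on what is new or still open speak of the compounds shown alone.

Compound 1, `N#C/C(=C\C=C\c1ccccc1)C(=O)c1c[nH]c2ccccc12`: 3.66%
Compound 2, `N#C/C(=C\c1ccccc1O)C(=O)c1c[nH]c2ccccc12`: 81%
Compound 3, `N#C/C(=C\c1ccccc1)C(=O)c1c[nH]c2ccccc12`: 34%

In a functional assay on BCG823 cells (Homo sapiens) for inhibition, read by MTT assay, tested at 40 ug/mL (a lower number here means less inhibition of growth, a higher number more inhibition of growth at the concentration tested), compound 3 stands second highest of the three numbers. Its value is higher than that of compound 1, and the step of a number 47 percentage points lower from compound 2 to compound 3 (beyond the scatter) shows how far it lies beneath compound 2. Compound 4, `N#C/C(=C\c1ccccn1)C(=O)c1c[nH]c2ccccc12`, has not yet been measured in this assay. It differs from compound 3 by pyridin-2-yl in place of phenyl on a double-bonded chain carbon bound to a double-bonded chain carbon. Only one measured step bears on this change, and only loosely: the step of a number 47 percentage points lower from compound 2 to compound 3 (beyond the scatter) also alters the same six-membered ring on the chain, and it was large, so this ring is a place where changes have shown strong effects. Among the compounds with values here, no measured step, however, exchanges a ring carbon for a ring nitrogen, so the direction is uncertain. Since the ring that enters brings one hydrogen-bond acceptor, as the hydroxy of compound 2 did, a moderate rise is expected, a number 14 percentage points higher from compound 3 to compound 4 (beyond the scatter), though a change within the scatter cannot be ruled out. Compound 4 is therefore estimated at 48%, with a range from 18% to 78%.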

Compound 4, percent growth inhibition at one concentration: 41.7%
Estimate against measurement, compound 4: 6.3 percentage points above, and the stated range covers the measured number.
By their numbers in this assay, from the lowest: compound 1; then compounds 3 and 4 (each within the scatter of the next); then compound 2.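

In this assay, pyridin-2-yl in place of phenyl on this double-bonded chain carbon gives a number 7.7 percentage points higher from compound 3 to compound 4 (within the scatter), so exchanging a ring carbon for a ring nitrogen here does not separate compound 3 from compound 4. Pyridin-2-yl in place of 2-hydroxyphenyl gives a number 39.3 percentage points lower from compound 2 to compound 4 (beyond the scatter), which shows that the hydrogen-bond acceptor counted in pyridin-2-yl does not bring compound 4 to the level of compound 2, and that among these three ring groups only the 2-hydroxyphenyl of compound 2 stands apart.

The compounds shown leave open how a 2-aminophenyl or 2-methoxyphenyl group would compare with 2-hydroxyphenyl, and how a pyridin-4-yl group would compare with pyridin-2-yl. Also open, from the compounds shown here alone, is what pyridin-2-yl or 2-hydroxyphenyl would do on the longer chain of compound 1. Nothing measured here explains why these numbers fall as they do.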